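Replacing the Phenyl of Compound 3 with Methyl

This account rests on a few compounds, and the source may have more. Where it says the series, first, only, none or still open, it means among the compounds named here.

Compound 3 `OC(CCn1nc2c(Br)c(Br)c(Br)c(Br)c2n1)c1ccccc1` is the parent of a small set whose shared core is bound through a saturated chain to a hydroxyl-bearing carbon. In a functional assay on MCF7 cells (Homo sapiens) for antiproliferative activity, read by MTT assay, with a stated time of 24 h, tested at 50 uM (on this read-out higher numbers stand for a weaker effect at the one concentration tested and lower numbers for a stronger effect), compound 3 gives 28%, level with compound 2 `OC(CCn1nc2c(Br)c(Br)c(Br)c(Br)c2n1)c1cccc(Cl)c1`, which gives 28%, and together these are the highest two of the three numbers; compound 1 `OC(CCn1nc2c(Br)c(Br)c(Br)c(Br)c2n1)c1cccc(Br)c1` gives 14%, and the change was a number 14 percentage points higher from compound 1 to compound 3 (beyond the scatter). Compound 4 `CC(O)CCn1nc2c(Br)c(Br)c(Br)c(Br)c2n1` differs from compound 3 by methyl in place of phenyl on a saturated chain carbon bound to an oxygen on a saturated carbon and a saturated chain carbon. Within the data shown here, no measured step removes the phenyl itself: the steps of a number 14 percentage points higher from compound 1 to compound 2 (beyond the scatter) and no change at the digits printed from compound 2 to compound 3 (within the scatter) alter only a group on that ring, and the largest of them was modest. Among the measured compounds shown here, the change to compound 4 is bigger than any of these, so no measured step tells its direction with confidence. Compound 4 is therefore expected to lie somewhat above compound 3, estimated at 45% with a range from 22% to 70%, a step of a number 17 percentage points higher from compound 3 to compound 4 (beyond the scatter) that is itself uncertain.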

Compound 4, a percentage reported as activity, at one concentration (the size of the read-out at that concentration, not a potency): 90%
Beside the measured number, compound 4's estimate is 45 percentage points below it, and the stated range ends below it.
By their numbers in this assay, from the lowest: compound 1; then compounds 2 and 3 (each within the scatter of the next); then compound 4.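

Among these compounds, exchanging the aromatic ring for methyl at this carbon gives the first large step in the set in this assay, a number 62 percentage points higher from compound 3 to compound 4 (beyond the scatter), and the step stays large whichever ring leaves, with a number 62 percentage points higher from compound 2 to compound 4 (beyond the scatter) and a number 76 percentage points higher from compound 1 to compound 4 (beyond the scatter). On this read-out a higher number stands for a weaker effect, so the effect at the one concentration tested is much weaker with methyl than with phenyl, 3-chlorophenyl or 3-bromophenyl, a far bigger shift than any change on the ring itself gave. Nothing measured here speaks to what lies behind this step.

From the compounds shown here alone, whether a cyclohexyl group, a benzyl group or a longer chain such as butyl at this carbon would behave like phenyl or like methyl remains open. So does how a methoxy group or an amine on the phenyl would compare with the 3-bromophenyl of compound 1.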